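Cytotoxicity in the aryl-oxazole series: the tert-butyl step

The compounds below may be only part of what the source reports. "The series", "measured", "known", "first", "only" and "open" are said of these compounds alone.

In an ADME assay on HEK293 cells (Homo sapiens) for cytotoxicity, read by MTT assay, with a stated time of 36 h (on this read-out higher numbers stand for weaker inhibition and lower numbers for stronger inhibition), compound 3 `Cc1ccc(-c2nc(CN3CCC(C(=O)c4ccc5c(c4)OCCO5)CC3)co2)cc1` gives > 150 ug/mL, a limit of the assay and not a number. Compound 1 `O=C(c1ccc2c(c1)OCCO2)C1CCN(Cc2coc(-c3ccc(C(F)(F)F)cc3)n2)CC1` gives > 150 ug/mL, likewise a limit. Compound 2 `O=C(c1ccc2c(c1)OCCO2)C1CCN(Cc2coc(-c3ccccc3F)n2)CC1` gives > 150 ug/mL, also a limit. The steps a step that the two limits leave unreadable from compound 1 to compound 2, a step that the two limits leave unreadable from compound 1 to compound 3 and a step that the two limits leave unreadable from compound 2 to compound 3 therefore carry no readable size; all three values sit at the limit of > 150 ug/mL in this assay, at which 3 of the 3 values shown sit. Compound 4 `CC(C)(C)c1ccc(-c2nc(CN3CCC(C(=O)c4ccc5c(c4)OCCO5)CC3)co2)cc1` carries tert-butyl in place of methyl on an aromatic carbon. The measured steps bear on this change only in that each aryl substituent tried so far has stayed at the limit in this assay; no readable step exists, so no step beyond the scatter is expected from compound 3 to compound 4, a number no higher from compound 3 to compound 4 (the limit leaves the size open) being the expectation. Compound 4 is expected to give 150 ug/mL, between 75 ug/mL and 300 ug/mL, most likely again as a limit.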

Compound 4, half-maximal inhibitory concentration: > 150 ug/mL
Compound 4 ended at the assay's limit (the forecaster's own chance of this, stated with the estimate: 85%); the middle value lies on the limit itself.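

In this assay no step can be read among compound 1, compound 2, compound 3 and compound 4, which all stand at one limit: the limit of > 150 ug/mL in this assay, at which 4 of the 4 values shown sit. The compounds shown leave open where their actual values lie, and whether any aryl substituent shifts them.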